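Acid side-chain variants at the carbonyl carbon: compound 3

A few compounds are considered here, and "the series" means these few. Any claim that something is new, unique, unknown or untested is made for them only; others in the source may bear on it.

Measured so far:
Compound 1 `CCCCCCc1c(C(=O)CCC(C)(C)C(=O)O)c2cc(Cl)ccc2n1C`: in a functional assay on isolated protein for antagonist activity at Oxoeicosanoid receptor 1 (Homo sapiens), read by fluorescence and calcium flux, with stated times of 2 min and 1 min (a lower number here means a stronger inhibitor, a higher number a weaker inhibitor), compound 1 gives 4060 nM.
Compound 2 `CCCCCCc1c(C(=O)C(C)(C)CCC(=O)O)c2cc(Cl)ccc2n1C`: in this assay compound 2 gives 8150 nM.

Two compounds share one core and differ only in the acid-bearing chain on the carbonyl carbon. Compound 2 and compound 1 sit within the scatter of each other: the step of a 2.0-fold higher number from compound 1 to compound 2 (0.30 log units; within the scatter) does not exceed it, so no order between the two can be read from these numbers.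

Compound 3 `CCCCCCc1c(C(=O)CC2(CC(=O)O)CC2)c2cc(Cl)ccc2n1C` continues the same theme. The change is (1-(carboxymethyl)cyclopropyl)methyl in place of 3-carboxy-1,1-dimethylpropyl on a carbonyl carbon. Among the measured compounds shown here, the only measured step that bears on it is the chain rearrangement from compound 1 to compound 2, which moved the two methyl groups along the chain and stayed within the scatter. Closing those two methyl groups into a three-membered ring and shifting the acid onto a carboxymethyl arm keeps the same atom count, donor and acceptor, and is a change of the same kind.

No step beyond the scatter is therefore expected in this assay. The expected step of a 1.2-fold lower number from compound 2 to compound 3 (0.07 log units; within the scatter) is estimated to lie within the scatter. For compound 3 the estimate is 7000 nM, with a range from 2500 nM to 20000 nM.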

Compound 3, half-maximal inhibitory concentration: 580 nM
Compound 3: middle estimate off by 12-fold (1.08 log units), on the high side; measured number outside the range, below it.
By their numbers in this assay, from the lowest: compound 3; then compounds 1 and 2 (each within the scatter of the next).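

In this assay the acid-bearing chain on the carbonyl carbon can move the number well beyond the scatter: (1-(carboxymethyl)cyclopropyl)methyl in place of 3-carboxy-1,1-dimethylpropyl gives a 14-fold lower number from compound 2 to compound 3 (1.15 log units; beyond the scatter) and, read against the chain of compound 1, the same group gives a 7.0-fold lower number from compound 1 to compound 3 (0.85 log units; beyond the scatter) with compound 3 lower in both comparisons. The two open chains stay within the scatter of each other, so only the chain of compound 3 separates from the others at this position. The leaving and entering groups match in heavy atoms, donor and acceptor, so those counts alone do not fix the number here, and no measurement at hand accounts for the size of the step.

The compounds shown leave open whether the three-membered ring or the placement of the acid carries the step, and an open-chain 3-carboxy-2,2-dimethylpropyl group on the carbonyl carbon would separate the two. On these data alone, whether a cyclobutane ring in place of the cyclopropane ring keeps the lower number also remains open.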